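The source may report more compounds than this note shows. Statements on the series, on what has been measured and on what is new or still open speak of the compounds shown alone.

Compound 1 `CCCCCCCCc1ccc(OCC(=O)Cn2nnc(-c3ccc(Cl)cc3)n2)cc1` gives 35 nM in an assay on microsomes from brain for inhibition of Fatty-acid amide hydrolase 1 (Rattus norvegicus), read by fluorescence and HPLC, with a stated time of 60 min; a higher number here means a weaker inhibitor, a lower number a stronger inhibitor. Compound 2 `CCCCCCCCc1ccc(OCC(=O)Cn2nnc(-c3cccc(Cl)c3)n2)cc1` gives 24 nM in this assay.

Compound 2 has the lowest of the two numbers, though the step of a 1.5-fold lower number from compound 1 to compound 2 (0.16 log units; within the scatter) is within the scatter. Compound 3 `CCCCCCCCc1ccc(OCC(=O)Cn2nnc(-c3cccc(S(=O)(=O)N(C)C)c3)n2)cc1` differs from compound 2 by dimethylsulfamoyl in place of chloro on an aromatic carbon. Among the compounds with values here, no measured step covers this exchange; the only step known concerns the position of the chloro group, not its replacement. The expectation for compound 3 therefore rests on the change alone and is a 3.3-fold higher number from compound 2 to compound 3 (0.52 log units; beyond the scatter), with compound 3 estimated at 80 nM in this assay, within 20 nM to 320 nM.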

Compound 3, half-maximal inhibitory concentration: 420 nM
Compound 3: middle estimate off by 5.3-fold (0.72 log units), on the low side; the whole stated range lies below it.
By their numbers in this assay, from the lowest: compounds 2 and 1 (each within the scatter of the next); then compound 3.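

Moving the chloro group in the earlier compounds gave no step beyond the scatter, but replacing it does: in this assay dimethylsulfamoyl in place of chloro gives an 18-fold higher number from compound 2 to compound 3 (1.24 log units; beyond the scatter) and 3-(dimethylsulfamoyl)phenyl in place of 4-chlorophenyl gives a 12-fold higher number from compound 1 to compound 3 (1.08 log units; beyond the scatter) as well. This aromatic carbon therefore does not tolerate every group equally, at least for this one exchange. Nothing measured here explains the size of these steps. Still open, on these data alone, is how methoxy, a nitrile or an unsubstituted sulfamoyl would read at this carbon. Equally open, as far as these compounds go, is whether 4-(dimethylsulfamoyl)phenyl would give a similar number.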